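The source may report more compounds than this note shows. Statements on the series, on what has been measured and on what is new or still open speak of the compounds shown alone.

In a functional assay on HCT-116 cells (Homo sapiens) for positive allosteric modulation, read by MTT assay, with stated times of 24 h and 48 h, tested at 2.5 uM (on this read-out higher numbers stand for more inhibition of growth at the one concentration tested and lower numbers for less inhibition of growth), compound 1 `CS(=O)(=O)c1ccc(-c2cnc3[nH]cc(-c4nnc(-c5ccccc5)o4)c(=O)c3c2)cc1` gives 27.2%. Compound 2 `O=c1c(-c2nnc(-c3ccc(F)cc3)o2)c[nH]c2ncc(-c3cccnc3)cc12` gives 20.1% in this assay; the two numbers lie within the usual scatter of each other, so neither stands apart. Compound 3 `CS(=O)(=O)c1ccc(-c2cnc3[nH]cc(-c4nnc(-c5cccnc5)o4)c(=O)c3c2)cc1` differs from compound 1 in one place: pyridin-3-yl in place of phenyl on an aromatic carbon. Among the measured compounds shown here, no pair of measured compounds is separated by exactly this change, so the data offer no step to lean on. The step of a number 3.2 percentage points lower from compound 1 to compound 3 (within the scatter) is expected to stay within the scatter, in no clear direction. Compound 3 is estimated at 24% in this assay, with a range from 10% to 38%.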

Compound 3, percent growth inhibition at one concentration: 28.6%
Beside the measured number, compound 3's estimate is 4.6 percentage points below it; measured number inside the range.
By their numbers in this assay, from the lowest: compounds 2, 1 and 3 (each within the scatter of the next).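

In this assay, pyridin-3-yl in place of phenyl on this aromatic carbon of the five-membered ring gives a number 1.4 percentage points higher from compound 1 to compound 3 (within the scatter), the first step read at this position. At this one concentration, a ring with one hetero atom and a ring of carbon only cannot be told apart here. Nothing available offers an explanation for this result.

Open, from the compounds shown here alone, is whether an amine or a carboxylic acid on this ring, or a longer chain in its place, would move the number beyond the scatter. Also open, going by these compounds, is whether this step would hold on other cores.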